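The source may hold more compounds than are shown below. What is called first, only, known or untested is meant among the compounds shown, and "the series" means these compounds.

Working notes on the series, read in a physicochemical assay for solubility, read by HPLC, at pH 7.4; on this read-out higher numbers stand for higher solubility and lower numbers for lower solubility. Compound 1 (`CCn1c(C(=O)N[C@H](CO)C(C)C)ccc1C(CC)(CC)c1ccc(OCS(=O)(=O)c2ccccc2)c(C)c1`) gives 27.8 ug/mL. Compound 2 (`CCN(CC)CCNC(=O)c1cc(C(CC)(CC)c2ccc(OCSC)c(C)c2)cn1CC`) gives 198 ug/mL, the higher of the two numbers, and its gap to compound 1 lies beyond the scatter. Compound 3 (`CCN(CC)CCNC(=O)c1cc(C(CC)(CC)c2ccc(OCSc3ccccc3)c(C)c2)cn1CC`) follows from compound 2 with phenyl in place of methyl on a sulfur, whose other neighbour is a saturated chain carbon: phenyl in place of methyl on a sulfur. Going by the values given here, the two measured compounds differ in more than one place, so no measured single-place step is available to size this change, and the expectation rests on the counted difference alone. A downward move beyond the scatter is expected. The estimated step is a 3.3-fold lower number from compound 2 to compound 3 (0.52 log units; beyond the scatter). For compound 3 the expected value is 60 ug/mL, with an estimated range of 15 ug/mL to 170 ug/mL.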

Compound 3, solubility: 0.6 ug/mL
For compound 3 the middle estimate is 100-fold (2.00 log units) above the measured one, outside the stated range (below it).
By their numbers in this assay, from the lowest: compound 3; then compound 1; then compound 2.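

In this assay, the sulfur substituent is a place where a single change carries a large effect: phenyl in place of methyl on a sulfur gives a 330-fold lower number from compound 2 to compound 3 (2.52 log units; beyond the scatter), with the rest of the structure unchanged. Going by these compounds alone, this is the first single-place step, and it sizes a change that the earlier pair, differing in more than one place, could not. The change adds one six-membered aromatic ring of carbon only, and nothing at hand says what lies behind a step of this size.

Only methyl and phenyl are shown on this sulfur, so it remains open where an ethyl or a benzyl group would fall. Also open, going by these compounds, is whether a pyridyl ring, or a phenyl carrying a carboxylic acid, would keep the number closer to that of compound 2.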